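Working notes: step from compound 3 to compound 4

The compounds below may be only part of what the source reports. "The series", "measured", "known", "first", "only" and "open" are said of these compounds alone.

Measured so far, in a functional assay on MCF7 cells (Homo sapiens) for cytotoxicity, read by MTT assay, with a stated time of 72 h; on this read-out higher numbers stand for weaker inhibition and lower numbers for stronger inhibition:
compound 1 `O=C(Nc1ccc(Oc2ccnc3[nH]ccc23)cc1)c1nn(-c2ccc(Cl)cc2)ccc1=O` gives 10600 nM
compound 2 `Cc1cc(=O)n(-c2ccc(F)cc2)nc1C(=O)Nc1ccc(Oc2ncnc3[nH]ccc23)cc1` gives 4800 nM
compound 3 `Cc1cc(=O)n(-c2ccc(F)cc2)nc1C(=O)Nc1ccc(Oc2ncnc3[nH]ccc23)c(F)c1` gives 24500 nM

Compound 3 stands at the highest number of the three in this assay. For the measured compounds named here, the one single-point step measured, a 5.1-fold higher number from compound 2 to compound 3 (0.71 log units; beyond the scatter), concerns fluoro in place of hydrogen on the anilide ring and does not touch the aryl on the ring nitrogen. Compounds 1 and 2 differ from each other in several places at once, so their values only show that both lie below compound 3.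

Compound 4 `Cc1cc(=O)n(-c2cccc(C(F)(F)F)c2)nc1C(=O)Nc1ccc(Oc2ncnc3[nH]ccc23)c(F)c1` differs from compound 3 by 3-(trifluoromethyl)phenyl in place of 4-fluorophenyl on an aromatic nitrogen. Going by the values given here, no measured step bears on a change of the aryl on the ring nitrogen, so there is no precedent of known size for it. With nothing to go on beyond the three values, compound 4 is expected to stay near compound 3, with a step of a 1.4-fold lower number from compound 3 to compound 4 (0.13 log units; within the scatter) that may well fall within the scatter in either direction. Compound 4 is estimated at 18000 nM, with a range from 5000 nM to 60000 nM in this assay.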

Compound 4, half-maximal inhibitory concentration: 11800 nM
Beside the measured number, compound 4's estimate is 1.5-fold (0.18 log units) above it; the range from low to high includes it.
By their numbers in this assay, from the lowest: compound 2; then compounds 1 and 4 (each within the scatter of the next); then compound 3.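

In this assay, the aryl on the ring nitrogen is now shown to be a place where the number can move beyond the scatter: replacing 4-fluorophenyl with 3-(trifluoromethyl)phenyl gives a 2.1-fold lower number from compound 3 to compound 4 (0.32 log units; beyond the scatter). For the compounds shown here, the only earlier single-place step, a 5.1-fold higher number from compound 2 to compound 3 (0.71 log units; beyond the scatter), came from fluoro in place of hydrogen on an aromatic carbon elsewhere in the molecule and ran towards higher numbers, so this is the first measured change that runs towards lower numbers. No measurement is available that accounts for this step.

The change replaces the fluoro group with trifluoromethyl and also moves the substituent from the 4-position to the 3-position of the phenyl, so the compounds shown cannot separate the contribution of the group from that of its position, and the step is known only on the fluorinated background of compound 3. Also open, on these data alone, is how the number would respond to a methoxy group or an amine on that phenyl, or to a plain alkyl chain in place of the aryl on the ring nitrogen.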